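Three Anilides Measured, a Nitro Anilide Estimated

The source may hold more compounds than are shown below. What is called first, only, known or untested is meant among the compounds shown, and "the series" means these compounds.

Measured compounds:
compound 1, `Cc1cc(C#N)cc(C)c1Oc1ccnc(S(=O)(=O)CC(=O)Nc2ccc(F)cc2)n1`: 26100 nM
compound 2, `Cc1cc(C#N)cc(C)c1Oc1ccnc(S(=O)(=O)CC(=O)Nc2ccccc2Cl)n1`: 12500 nM
compound 3, `Cc1cc(C#N)cc(C)c1Oc1ccnc(S(=O)(=O)CC(=O)Nc2ccc(Br)cc2)n1`: 15600 nM

In an ADME assay on MT4 cells (Homo sapiens) for cytotoxicity, read by MTT assay, with a stated time of 4 days (a higher number here means that more compound is tolerated, a lower number that less compound is tolerated), compound 3 gives 15600 nM, the second highest of the three numbers. Its gap to the nearest neighbour, a 1.2-fold higher number from compound 2 to compound 3 (0.10 log units; within the scatter), lies within the scatter, and its gap to the furthest, a 1.7-fold lower number from compound 1 to compound 3 (0.22 log units; within the scatter), also lies within the scatter. Among the compounds with values here, the one change among the measured compounds that exceeded the scatter was a 2.1-fold lower number from compound 1 to compound 2 (0.32 log units; beyond the scatter), a modest step.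

Compound 4, `Cc1cc(C#N)cc(C)c1Oc1ccnc(S(=O)(=O)CC(=O)Nc2cccc([N+](=O)[O-])c2)n1`, differs from compound 3 by 3-nitrophenyl in place of 4-bromophenyl on an amide-type nitrogen. Within the data shown here, the steps that bear on this change are those at the same amide-type nitrogen: a 2.1-fold lower number from compound 1 to compound 2 (0.32 log units; beyond the scatter) and a 1.2-fold higher number from compound 2 to compound 3 (0.10 log units; within the scatter). All three measured anilides sit in a narrow band, and the largest step among them was only modest, so a change at the same place is expected to move the number in this assay little, if at all beyond the scatter. Among the measured compounds shown here, no measured compound carries a nitro group, so the direction of any small shift cannot be read from the data. The expected step is a 1.0-fold higher number from compound 3 to compound 4 (0.01 log units; within the scatter). Compound 4 is therefore estimated at 16000 nM, within a range from 7000 nM to 36000 nM.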

Compound 4, half-maximal cytotoxic concentration: 23600 nM
Estimate against measurement, compound 4: 1.5-fold (0.17 log units) below; the range from low to high includes it.
By their numbers in this assay, from the lowest: compounds 2, 3, 4 and 1 (each within the scatter of the next, the first and the last beyond it).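

In this assay, replacing the halogen-bearing anilides with 3-nitrophenyl at the amide-type nitrogen gives a 1.5-fold higher number from compound 3 to compound 4 (0.18 log units; within the scatter), a 1.9-fold higher number from compound 2 to compound 4 (0.28 log units; within the scatter) and a 1.1-fold lower number from compound 1 to compound 4 (0.04 log units; within the scatter). Within the data shown here, the earlier compounds carried only fluoro, chloro or bromo on the phenyl ring, so compound 4 is the first to show that a group of a different kind, with more heavy atoms and two hydrogen-bond acceptors, can enter at this place and remain within the scatter of all three. Compound 4 also sits within the scatter of both compound 1 and compound 2, the two anilides that lie beyond the scatter of each other, so it does not widen the band, and nothing available explains why this change has so little effect.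

The compounds shown leave open whether the band would hold for a phenyl ring carrying an amine or a carboxylic acid, or for a longer chain on the amide-type nitrogen in place of the ring. Because the step from 4-bromophenyl to 3-nitrophenyl alters both the group and where it sits on the ring, the two contributions also remain unseparated.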